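This account rests on a few compounds, and the source may have more. Where it says the series, first, only, none or still open, it means among the compounds named here.

Among the compounds with values here, compound 1, with the structure `Nc1scc(CN2CCN(c3ccncc3)CC2)c1C(=O)c1ccc(Cl)cc1`, is one of two compounds measured in an assay on CHO cells for displacement of a labelled ligand from adenosine receptor A3 (Homo sapiens), read by scintillation counting, with a stated time of 120 min, tested at 10 uM (a higher number here means more inhibition at the concentration tested (going by the name of the read-out), a lower number less inhibition), where compound 1 gives 2%. That is the highest of the two numbers, but only by a margin within the usual scatter: compound 2, with the structure `Nc1scc(CN2CCN(c3ccc(C(F)(F)F)cc3)CC2)c1C(=O)c1cccc(C(F)(F)F)c1`, gives 0% in this assay, so the two readings cannot be told apart. Neither compound shows appreciable displacement at the concentration tested. Compound 3, with the structure `Nc1scc(CN2CCN(c3c(F)cc(F)cc3F)CC2)c1C(=O)c1ccc(Cl)cc1`, is not yet measured. It is related to compound 1 by a single change: 2,4,6-trifluorophenyl in place of pyridin-4-yl on an amine nitrogen in a ring. Within the data shown here, no step between the two measured compounds on the same structural change is available. Since compound 1 gives 2% and compound 2 gives 0%, the expected step of a number 1 percentage points higher from compound 1 to compound 3 (within the scatter) is none beyond the scatter. Compound 3 is therefore estimated at 3% in this assay, within a range from -6% to 12%.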

Compound 3, a percentage reported as inhibition, at one concentration (the size of the read-out at that concentration, not a potency): 0%
Beside the measured number, compound 3's estimate is 3 percentage points above it; low and high end bracket the measured number.
By their numbers in this assay, from the lowest: compounds 2, 3 and 1 (each within the scatter of the next).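

Placing 2,4,6-trifluorophenyl in place of pyridin-4-yl on an amine nitrogen in a ring gives a number 2 percentage points lower from compound 1 to compound 3 (within the scatter) in this assay, the first step that can be read at this position. Compound 1, whose group has one hydrogen-bond acceptor, and compound 3, whose group has none, therefore cannot be told apart here, and neither aromatic ring brings appreciable displacement at the concentration tested. Nothing measured here offers an explanation for this result.

Going by these compounds, it remains open whether an aliphatic amine, a carboxylic acid or a longer alkyl chain at this position would give a reading beyond the scatter. With all readings so close to nothing, the step also leaves open how these groups would compare in a compound that clearly displaces the ligand.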